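Swapping Dimethoxyphenyl for Naphthyl on a Shared Core

The source may report more compounds than this note shows. Statements on the series, on what has been measured and on what is new or still open speak of the compounds shown alone.

Measured in a functional assay on MCF7 cells (Homo sapiens) for antiproliferative activity, read by MTT assay, with stated times of 24 h and 72 h; on this read-out higher numbers stand for weaker inhibition and lower numbers for stronger inhibition:
Compound 1 `COc1ccc([C@@H]2[C@H](Oc3ccccc3)C(=O)N2c2cc(OC)c(OC)c(OC)c2)cc1OC`: 26000 nM
Compound 2 `COc1cc(N2C(=O)[C@H](Oc3ccccc3)[C@H]2c2ccc(C#N)cc2)cc(OC)c1OC`: 168000 nM

Compound 1 holds the lower of these two numbers, which makes it the stronger inhibitor of the pair. Compound 2, at 168000 nM, stands higher by a gap beyond the usual scatter.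

Compound 3 `COc1cc(N2C(=O)[C@@H](Oc3ccccc3)[C@H]2c2ccc3ccccc3c2)cc(OC)c1OC` has not yet been measured. Compared with compound 1, it carries naphthalen-2-yl in place of 3,4-dimethoxyphenyl on a saturated ring carbon. Going by the values given here, no pair of measured compounds shows what this change does, so any expectation is loose, and compound 1 at 26000 nM is the natural starting point. In this assay the expected step is a 1.2-fold higher number from compound 1 to compound 3 (0.06 log units; within the scatter), none beyond the scatter. The estimate for compound 3 is 30000 nM, with an expected range from 8000 nM to 110000 nM.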

Compound 3, half-maximal inhibitory concentration: 282000 nM
The estimate for compound 3 lay 9.4-fold (0.97 log units) below the measured number; the measured number lies above the stated range.
By their numbers in this assay, from the lowest: compound 1; then compounds 2 and 3 (each within the scatter of the next).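

Putting naphthalen-2-yl in place of 3,4-dimethoxyphenyl on a saturated ring carbon gives an 11-fold higher number from compound 1 to compound 3 (1.04 log units; beyond the scatter) in this assay, so the group at this position strongly affects the read-out. The two groups have the same heavy-atom count, so that count alone does not track the step; the change removes two hydrogen-bond acceptors and adds a second six-membered aromatic ring. This single pair cannot separate those differences, and no supporting measurement explains the weaker inhibition.

Still open, going by these compounds, is whether a pyridine ring or a phenyl ring carrying a hydroxyl group at this position would stay close to compound 1. Also open, on these data alone, is whether the same swap would have a similar effect if an amine replaced the phenoxy group.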